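A few compounds are considered here, and "the series" means these few. Any claim that something is new, unique, unknown or untested is made for them only; others in the source may bear on it.

Compound 2 `CCc1n[nH]c(C(=O)O)c1Cc1cccc(-c2ccc(F)cc2)c1` stands lowest of the two numbers in an assay on isolated protein for inhibition of 2-Hydroxyacid oxidase 2 (Homo sapiens), tested at 1 uM (on this read-out higher numbers stand for a stronger effect at the one concentration tested and lower numbers for a weaker effect), where compound 2 gives 5%; compound 1 `Cc1n[nH]c(C(=O)O)c1Cc1cc2ccccc2o1` gives 26% in this assay, a gap beyond the scatter. Compound 3 `CC(C)c1n[nH]c(C(=O)O)c1Cc1cccc(-c2ccc(F)cc2)c1` carries the change (methyl in place of hydrogen on a saturated chain carbon bound to an aromatic carbon and a saturated chain carbon). Going by the values given here, no measured pair shows what this change does on its own, and the two values so far say nothing about it. The step of a number 3 percentage points higher from compound 2 to compound 3 (within the scatter) is expected to stay within the scatter, with no clear direction. Compound 3 is estimated at 8% in this assay, in the range 0% to 25%.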

Compound 3, a percentage reported as inhibition, at one concentration (the size of the read-out at that concentration, not a potency): 2%
The estimate for compound 3 lay 6 percentage points above the measured number, within the range that was stated.
By their numbers in this assay, from the lowest: compounds 3 and 2 (each within the scatter of the next); then compound 1.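

Ethyl to isopropyl, on a saturated chain carbon bound to an aromatic carbon and a saturated chain carbon, gives a number 3 percentage points lower from compound 2 to compound 3 (within the scatter) in this assay at this single concentration. This first one-place comparison in the series therefore shows no readable effect of the added methyl on this read-out.

From the compounds shown here alone, whether a longer chain or a hydroxymethyl group at this place would separate from compound 2 remains open, as does whether the same change would read alike on the core of compound 1. No supporting data bear on the reason for this result.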